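This account rests on a few compounds, and the source may have more. Where it says the series, first, only, none or still open, it means among the compounds named here.

Working notes on the series. Within the data shown here, in a functional assay on MDA-MB-231 cells (Homo sapiens) for antiproliferative activity, read by MTT assay, with a stated time of 48 h (a higher number here means a weaker inhibitor, a lower number a stronger inhibitor), the entry for compound 1 `COC(=O)/C(=C/c1ccccc1)CN1C(=O)[C@@H](OC)[C@H]1c1cccc(Cl)c1` reads no result reported, so compound 2 `CCOC(=O)/C(=C/c1ccccc1)CN1C(=O)[C@@H](OC)[C@H]1c1cccc([N+](=O)[O-])c1`, at 14400 nM, supplies the only number available. It therefore cannot be ranked against any other member of the series, and nothing yet shows whether this value is high or low for the shared core.

The next compound is compound 3 `CCOC(=O)/C(=C/c1ccccc1)CN1C(=O)[C@@H](OC)[C@H]1c1ccc(F)cc1`, with 4-fluorophenyl in place of 3-nitrophenyl on a saturated ring carbon of the four-membered non-aromatic ring with 1 nitrogen, next to the ring nitrogen (4-fluorophenyl in place of 3-nitrophenyl on a saturated ring carbon). Among the measured compounds shown here, no two measured compounds differ in one place, so the data give no size or direction for this exchange. In this assay, no shift beyond the usual scatter is expected, and neither direction is favoured. The expectation is anchored on compound 2 at 14400 nM. The estimate is a 1.2-fold lower number from compound 2 to compound 3 (0.08 log units; within the scatter), a step expected to remain within the scatter. For compound 3 the estimated value is 12000 nM, with an expected range of 4000 nM to 36000 nM.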

Compound 3, half-maximal inhibitory concentration: 14000 nM
Compound 3: the middle estimate sits 1.2-fold (0.07 log units) below what was measured; low and high end bracket the measured number.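

In this assay, among these compounds, the exchange gives a 1.0-fold lower number from compound 2 to compound 3 (0.01 log units; within the scatter), which is the first measured step at this position on the saturated ring carbon. The step takes out 3-nitrophenyl, with 9 heavy atoms and 2 hydrogen-bond acceptors, and puts in 4-fluorophenyl, with 7 heavy atoms and 0 hydrogen-bond acceptors, yet the two compounds stay within the scatter of each other, so this one pair shows that the position can accept both aryl groups without a readable change in antiproliferative activity. The substituent and its place on the phenyl ring change together in this step, so their separate contributions cannot be read, and no measurement is at hand that would account for the result.

Still open, going by these compounds, is whether this flat response extends to groups of another kind on the phenyl ring, such as an amine or a carboxylic acid, since a single pair cannot show how far it reaches. Also open, on these data alone, is how the number responds at the ring atom that bears a methoxy group if a longer chain, such as a propoxy group, stands there instead.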